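Ring contraction of the amide substituent on the shared core

This account rests on a few compounds, and the source may have more. Where it says the series, first, only, none or still open, it means among the compounds named here.

Working notes. Of the compounds shown here, three on the shared core, differing at the amine nitrogen in a ring, have numbers so far. In an assay on isolated protein for displacement of a labelled ligand from secreted frizzled-related protein 1 (Homo sapiens), read by fluorescence polarization, with a stated time of 30 min (a lower number here means a stronger inhibitor, a higher number a weaker inhibitor), compound 1 `O=C(c1ccc(Cl)nc1)N1CCC(NS(=O)(=O)c2cc(S(=O)(=O)c3ccccc3)ccc2C(F)(F)F)CC1` gives 110 nM. Compound 2 `N#Cc1cccc(S(=O)(=O)N2CCC(NS(=O)(=O)c3cc(S(=O)(=O)c4ccccc4)ccc3C(F)(F)F)CC2)c1` gives 90 nM in this assay, and compound 3 `O=C(C1CCNCC1)N1CCC(NS(=O)(=O)c2cc(S(=O)(=O)c3ccccc3)ccc2C(F)(F)F)CC1` gives 120 nM. Compound 3 has the highest of the three numbers, but both gaps to the others lie within the scatter: a 1.1-fold higher number from compound 1 to compound 3 (0.04 log units; within the scatter) and a 1.3-fold higher number from compound 2 to compound 3 (0.12 log units; within the scatter). The remaining step is also within the scatter: a 1.2-fold lower number from compound 1 to compound 2 (0.09 log units; within the scatter).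

Compound 4 `O=C([C@@H]1CCNC1)N1CCC(NS(=O)(=O)c2cc(S(=O)(=O)c3ccccc3)ccc2C(F)(F)F)CC1` differs from compound 3 by pyrrolidin-3-yl in place of piperidin-4-yl on a carbonyl carbon. Among the compounds with values here, no measured step alters this ring on its own; the nearest comparisons, the step from compound 1 to compound 3 and the step from compound 2 to compound 3, exchange the whole group on the amine nitrogen and move the number only within the scatter. A change beyond the scatter is therefore not expected in this assay, in either direction. Compound 4 is estimated at 130 nM, with a range from 60 nM to 300 nM, corresponding to an expected step of a 1.1-fold higher number from compound 3 to compound 4 (0.03 log units; within the scatter).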

Compound 4, half-maximal inhibitory concentration: 60 nM
For compound 4 the middle estimate is 2.2-fold (0.34 log units) above the measured one; measured number inside the range.
By their numbers in this assay, from the lowest: compounds 4, 2, 1 and 3 (each within the scatter of the next).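

In this assay, within the data shown here, the only step that alters this ring on its own, pyrrolidin-3-yl in place of piperidin-4-yl on a carbonyl carbon, gives a 2.0-fold lower number from compound 3 to compound 4 (0.30 log units; within the scatter) and so shows that this position accepts the smaller ring, with its one defined stereocentre, without a change beyond the scatter. The (pyrrolidin-3-yl)carbonyl group also stays level with the two other groups on the amine nitrogen, with a 1.5-fold lower number from compound 2 to compound 4 (0.18 log units; within the scatter) against the (3-cyanophenyl)sulfonyl group and a 1.8-fold lower number from compound 1 to compound 4 (0.26 log units; within the scatter) against the 6-chloropyridin-3-yl group, so the four compounds remain unseparated in this assay. Nothing at hand bears on why these numbers sit so close together.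

Going by these compounds, it remains open whether the mirror-image pyrrolidin-3-yl group, an azetidin-3-yl ring or an open-chain aminoethyl group on this carbonyl carbon would give a step beyond the scatter. Also open, on these data alone, is whether the ring nitrogen is needed at all, which a tetrahydrofuran-3-yl ring or a cyclopentyl ring in the same place would address.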